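Swapping the carbonyl substituent: from cyclopentyl to 3-fluorophenyl

The compounds below may be only part of what the source reports. "The series", "measured", "known", "first", "only" and "open" are said of these compounds alone.

Measured so far:
compound 1 `CCC(=O)N1CCCn2nc(COc3ccccc3)cc21`, 48%
compound 2 `O=C(C1CC1)N1CCCn2nc(COc3ccccc3)cc21`, 61%
compound 3 `O=C(C1CCCC1)N1CCCn2nc(COc3ccccc3)cc21`, 41%

All three compounds share one core and differ only in the group attached to the carbonyl carbon. In a functional assay on HEK293 cells for positive allosteric modulation of metabotropic glutamate receptor 5 (Homo sapiens), read by calcium flux (a lower number here means a smaller maximal response, a higher number a larger maximal response), compound 3 gives the lowest of the three numbers; it sits close to compound 1, while the gap to compound 2 is larger, as the step of a number 20 percentage points lower from compound 2 to compound 3 (beyond the scatter) shows. The step of a number 13 percentage points higher from compound 1 to compound 2 (beyond the scatter) is of similar size in the opposite direction, whereas a number 7 percentage points lower from compound 1 to compound 3 (within the scatter) is small.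

Compound 4 `O=C(c1cccc(F)c1)N1CCCn2nc(COc3ccccc3)cc21` is not yet measured. It differs from compound 3 by 3-fluorophenyl in place of cyclopentyl on a carbonyl carbon. The measured steps only compare small alkyl groups on that carbonyl carbon, so none of them tests an aromatic ring there; they show that this position can shift the maximal response by modest amounts in either direction. Compound 4 is therefore expected to stay near compound 3, with a number 4 percentage points higher from compound 3 to compound 4 (within the scatter) as the estimated step, that is no change beyond the scatter. For compound 4 the estimate is 45%, expected to fall between 25% and 70%.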

Compound 4, largest response reached (reported as percent of maximum), in percent of the reference or control that the assay uses: 61%
Estimate against measurement, compound 4: 16 percentage points below, and the stated range covers the measured number.
By their numbers in this assay, from the lowest: compounds 3 and 1 (each within the scatter of the next); then compounds 2 and 4 (each within the scatter of the next).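

In this assay, an aromatic ring on the carbonyl carbon is tolerated: replacing cyclopentyl with 3-fluorophenyl gives a number 20 percentage points higher from compound 3 to compound 4 (beyond the scatter), and replacing ethyl with it gives a number 13 percentage points higher from compound 1 to compound 4 (beyond the scatter). Replacing cyclopropyl with 3-fluorophenyl gives no change at the digits printed from compound 2 to compound 4 (within the scatter), so two very different rings can give the same reading at this position, and a group with more heavy atoms than cyclopentyl need not lower the maximal response. No measurement shown here explains these differences.

From the compounds shown here alone, what the fluorine itself contributes remains open, and a plain phenyl group on the same carbonyl carbon would separate its share from that of the ring. A pyridine ring or a phenyl ring carrying an amine would show how far this position accepts nitrogen-containing aromatic groups.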